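Chloro onto the anilide ring of the shared core

The compounds below may be only part of what the source reports. "The series", "measured", "known", "first", "only" and "open" are said of these compounds alone.

Compound 3 `CC(CSc1nnc(-c2ccncc2)s1)C(=O)Nc1ccccc1` was tested in an ADME assay on BHK-21 cells (Mesocricetus auratus) for cytotoxicity, with a stated time of 3 days (on this read-out higher numbers stand for lower toxicity in this test and lower numbers for higher toxicity in this test), and in that test compound 3 gives > 50000 nM, which is a limit of the assay rather than a number. Compound 2 `CC(CSc1nnc(-c2ccncc2)s1)C(=O)Nc1c(Cl)cccc1Cl` gives > 50000 nM in this assay, also a limit. Compound 1 `O=C(CCSc1nnc(-c2ccncc2)s1)Nc1ccccc1Cl` gives > 50000 nM in this assay, again a limit. For the measured compounds named here, the one comparable step is a step that the two limits leave unreadable from compound 2 to compound 3. Compound 4 `CC(CSc1nnc(-c2ccncc2)s1)C(=O)Nc1ccccc1Cl` differs from compound 3 by chloro in place of hydrogen on an aromatic carbon. Going by the values given here, no measured step can size this change, because every value shown sits at the limit of > 50000 nM in this assay, at which 3 of the 3 values shown sit. The expected step is therefore a step that the limit leaves unreadable from compound 3 to compound 4, nothing beyond the scatter. Compound 4 is estimated to give 60000 nM in this assay, between 30000 nM and 150000 nM, most likely reported once more as a limit.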

Compound 4, half-maximal cytotoxic concentration: > 50000 nM
Compound 4: only a limit was reported; the forecaster's own chance of this, stated with the estimate: 85%; the middle value does not contradict the limit.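

No new step can be read between compound 1, compound 2, compound 3 and compound 4, since none of their results is an exact number: the limit of > 50000 nM in this assay, at which 4 of the 4 values shown sit. The compounds shown leave open whether any of these changes alters toxicity in this assay.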